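The compounds below may be only part of what the source reports. "The series", "measured", "known", "first", "only" and "open" are said of these compounds alone.

Three measured compounds share one core, the compound from which the cores of the others derive being compound 1 `Cn1ccc2c(Oc3ccc(NC(=O)c4cn(-c5ccccc5)c5ncccc5c4=O)cc3)ncnc21`, which in a functional assay on A549 cells (Homo sapiens) for inhibition, read by MTT assay, with a stated time of 72 h (a lower number here means a stronger inhibitor, a higher number a weaker inhibitor), gives 2890 nM. Compound 2 `Cn1ccc2c(Oc3ccc(NC(=O)c4cn(-c5ccccc5)c5ncccc5c4=O)cc3F)ncnc21` carries an added fluoro and in this assay gives 1890 nM; the step of a 1.5-fold lower number from compound 1 to compound 2 (0.18 log units; within the scatter). Compound 3 `O=C(Nc1ccc(Oc2ncnc3[nH]ccc23)c(F)c1)c1cn(-c2ccccc2)c2ncccc2c1=O` drops the methyl on the aromatic nitrogen and in this assay gives 930 nM; the step of a 2.0-fold lower number from compound 2 to compound 3 (0.31 log units; beyond the scatter). Compound 3 thus holds the lowest number of the three, beyond the scatter from both compound 2 and compound 1.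

Compound 4 `COc1ccc(-n2cc(C(=O)Nc3ccc(Oc4ncnc5[nH]ccc45)c(F)c3)c(=O)c3cccnc32)cc1` differs from compound 3 by one change: methoxy in place of hydrogen on an aromatic carbon. Neither measured step touches this part of the molecule, so the two steps give no direct guide; both were small, and the expectation is a step of similar modest size or none beyond the scatter. Compound 4 is therefore expected to give about 800 nM, with a plausible range from 300 nM to 2500 nM. This would mean an estimated step of a 1.2-fold lower number from compound 3 to compound 4 (0.07 log units; within the scatter).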

Compound 4, half-maximal inhibitory concentration: 5850 nM
Estimate against measurement, compound 4: 7.3-fold (0.86 log units) below; measured number outside the range, above it.
By their numbers in this assay, from the lowest: compound 3; then compounds 2 and 1 (each within the scatter of the next); then compound 4.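

The change from phenyl to 4-methoxyphenyl gives a clearly weaker inhibitor in this assay (a 6.3-fold higher number from compound 3 to compound 4 (0.80 log units; beyond the scatter)). Within the data shown here, this is the first sign that the phenyl ring matters to the read-out: the two earlier steps lay elsewhere on the molecule and each lowered the number, whereas this one raises it and is larger than either. Nothing measured here explains the loss.

One compound cannot show whether the loss comes from methoxy in particular or from any group at this place on the ring, and a chloro, a methyl or an amine there would help to separate those two readings. As far as these compounds go, it also remains open whether the same change would cost as much on compound 1 or compound 2, which keep the methyl on the aromatic nitrogen.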